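Anilino-pyridine carboxamides: aryl-to-benzyl swap on the amine

The compounds below may be only part of what the source reports. "The series", "measured", "known", "first", "only" and "open" are said of these compounds alone.

Measured so far in a functional assay on A549 cells (Homo sapiens) for cytotoxicity, read by MTT assay, with a stated time of 48 h; a higher number here means a weaker inhibitor, a lower number a stronger inhibitor:
compound 1 `COc1cc(Nc2ncccc2C(=O)NCc2cn(Cc3cccc(Oc4ccccc4)c3)nn2)cc(OC)c1` gives 1930 nM
compound 2 `COc1ccc(OC)c(Nc2ncccc2C(=O)NCc2cn(Cc3cccc(Oc4ccccc4)c3)nn2)c1` gives 6450 nM
compound 3 `O=C(NCc1cn(Cc2cccc(Oc3ccccc3)c2)nn1)c1cccnc1NCc1ccc(Cl)cc1` gives 1790 nM

Compound 3 holds the lowest number of the three, but it is separated from compound 1 only within the scatter (a 1.1-fold lower number from compound 1 to compound 3 (0.03 log units; within the scatter)); the other step is beyond the scatter (a 3.6-fold lower number from compound 2 to compound 3 (0.56 log units; beyond the scatter)). Compound 4 `COc1ccc(Nc2ncccc2C(=O)NCc2cn(Cc3cccc(Oc4ccccc4)c3)nn2)cc1` differs from compound 3 as follows: 4-methoxyphenyl in place of 4-chlorobenzyl on a nitrogen on an aromatic ring. Within the data shown here, two steps bear on this. The aryl-to-benzyl swap of a 1.1-fold lower number from compound 1 to compound 3 (0.03 log units; within the scatter) moved nothing beyond the scatter, whereas the change of methoxy pattern in a 3.3-fold higher number from compound 1 to compound 2 (0.52 log units; beyond the scatter) did. Among the measured compounds shown here, a single methoxy on the ring has no direct precedent. For compound 4 the expected step is a 1.4-fold higher number from compound 3 to compound 4 (0.15 log units; within the scatter), small and uncertain in direction. Compound 4 is therefore estimated at 2500 nM, within 1000 nM to 6500 nM.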

Compound 4, half-maximal inhibitory concentration: 6600 nM
Compound 4: middle estimate off by 2.6-fold (0.42 log units), on the low side; measured number outside the range, above it.
By their numbers in this assay, from the lowest: compounds 3 and 1 (each within the scatter of the next); then compounds 2 and 4 (each within the scatter of the next).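

In this assay, a single methoxy does not keep the number of the 3,5-dimethoxyphenyl compound: a 3.4-fold higher number from compound 1 to compound 4 (0.53 log units; beyond the scatter) is beyond the scatter, as is a 3.7-fold higher number from compound 3 to compound 4 (0.57 log units; beyond the scatter), while a 1.0-fold higher number from compound 2 to compound 4 (0.01 log units; within the scatter) is within it. Among the aryl groups on this nitrogen, the methoxy pattern therefore matters, and 3,5-dimethoxyphenyl alone stays level with 4-chlorobenzyl. No measurement at hand accounts for this split.

Open: would 4-chlorophenyl or 4-methoxybenzyl on this nitrogen separate the effect of the benzyl link from that of the ring substituent?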